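A few compounds are considered here, and "the series" means these few. Any claim that something is new, unique, unknown or untested is made for them only; others in the source may bear on it.

Measured compounds:
- compound 1 `Cc1cc(NC(=O)Cn2nnc(-c3ccccc3)n2)n(-c2ccccc2)n1`: 3020 nM in an assay on HEK293 cells for activation of Kir3.1/Kir3.2 (Homo sapiens), read by thallium flux; a lower number here means that less compound is needed, a higher number that more compound is needed for the effect
- compound 2 `Cc1cc(NC(=O)Cn2nnc(-c3ccc(Cl)c(Cl)c3)n2)n(C2CCCCC2)n1`: 1220 nM in this assay

Compound 2 stands at the lowest of the two numbers measured in this assay. Its nearest neighbour is compound 1, which gives 3020 nM, a gap that lies beyond the usual scatter of repeated measurements. The two compounds differ in more than one place, so nothing can be said about which part of compound 2 accounts for the difference.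

Compound 3 `Cc1cc(NC(=O)Cn2nnc(-c3ccc(C(F)(F)F)cc3)n2)n(C2CCCCC2)n1` has not yet been measured. It differs from compound 2 in one place: 4-(trifluoromethyl)phenyl in place of 3,4-dichlorophenyl on an aromatic carbon.

Within the data shown here, no step between measured compounds is available for this kind of change, so the expectation rests on compound 2 alone. Because compound 2 gives 1220 nM, compound 3 is expected to land close to it, with a step of a 1.5-fold higher number from compound 2 to compound 3 (0.17 log units; within the scatter) that is estimated to stay within the usual scatter, if anything slightly towards a higher number. Compound 3 is therefore estimated at 1800 nM, with a range from 600 nM to 5500 nM.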

Compound 3, half-maximal effective concentration: 241 nM
Beside the measured number, compound 3's estimate is 7.5-fold (0.87 log units) above it; the measured number lies below the stated range.
By their numbers in this assay, from the lowest: compound 3; then compound 2; then compound 1.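

Among these compounds, the step of a 5.1-fold lower number from compound 2 to compound 3 (0.70 log units; beyond the scatter) in this assay is the first comparison here that changes one place only, so it shows that the group on the aromatic carbon of the five-membered aromatic ring with 4 nitrogen affects the number by more than the usual scatter. With the rest of the structure unchanged, 4-(trifluoromethyl)phenyl gives a lower number than 3,4-dichlorophenyl, even though the entering group is the larger of the two by heavy-atom count. No measurement is available here that would explain this difference.

The change replaces two chlorine atoms with a trifluoromethyl group, so the compounds shown leave open whether the lower number goes with the trifluoromethyl group itself or with the removal of one or both chlorine atoms, a question that a 4-chlorophenyl or a 3-(trifluoromethyl)phenyl group at this place could help to separate. Going by these compounds, it also remains open whether other groups on the same phenyl ring, such as a nitrile, a methoxy group or an amine, would give a similar number, and whether this step would hold on the core of compound 1.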